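A few compounds are considered here, and "the series" means these few. Any claim that something is new, unique, unknown or untested is made for them only; others in the source may bear on it.

In an ADME assay on Vero cells (Chlorocebus sabaeus) for cytotoxicity, with a stated time of 72 h (a higher number here means a weaker inhibitor, a lower number a stronger inhibitor), compound 3 `CCOC(=O)c1cc(-c2cccc(OCc3cccc(F)c3F)c2)on1` gives only a limit of the assay, > 128000 nM, and not a number. Compound 1 `CCOC(=O)c1cc(-c2cccc(OCc3cccc(Br)c3)c2)on1` likewise returns only a limit in this assay, > 128000 nM. Compound 2 `CCOC(=O)c1cc(-c2cccc(OCc3cccc([N+](=O)[O-])c3)c2)on1` also stops at a limit in this assay, > 128000 nM. Because of the limit of > 128000 nM in this assay, at which 3 of the 3 values shown sit, none of the steps among these three can be sized: a step that the two limits leave unreadable from compound 1 to compound 2, a step that the two limits leave unreadable from compound 1 to compound 3 and a step that the two limits leave unreadable from compound 2 to compound 3 all stay unreadable. Compound 3 therefore stands where both of its neighbours stand, at the top of what this assay can report, with no ordering among the three.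

Compound 4 `CCOC(=O)c1cc(-c2cccc(OCc3ccc(F)cc3F)c2)on1` differs from compound 3 in one place: 2,4-difluorophenyl in place of 2,3-difluorophenyl on a saturated chain carbon bound to an oxygen on an aromatic ring. Within the data shown here, no measured step covers this exchange, and the two steps that touch compound 3 at all, from compound 1 and from compound 2, are themselves unreadable, so they give no size and no direction to carry over. The step from compound 3 to compound 4 is accordingly expected to be a step that the limit leaves unreadable from compound 3 to compound 4, nothing beyond the scatter in either direction. Compound 4 is estimated to give about 200000 nM in this assay, within a range from 128000 nM to 500000 nM, and most probably to be reported, like compound 3, only as a limit rather than a number.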

Compound 4, half-maximal inhibitory concentration: > 128000 nM
Compound 4: no number, only a limit; the forecaster's own chance of this, stated with the estimate: 90%; the middle value does not contradict the limit.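

In this assay compound 4 gives only a limit, > 128000 nM, and not a number. No step from compound 1, compound 2 or compound 3 to compound 4 can be read, as all four stop at the same limit: the limit of > 128000 nM in this assay, at which 4 of the 4 values shown sit.

The compounds shown leave open whether compound 1, compound 2, compound 3 and compound 4 differ at all in this assay, and in what order.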